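The source may report more compounds than this note shows. Statements on the series, on what has been measured and on what is new or still open speak of the compounds shown alone.

Measured so far in an ADME assay on BJ cells (Homo sapiens) for cytotoxicity, read by luminescence, with a stated time of 72 h; a lower number here means that less compound is needed, a higher number that more compound is needed for the effect:
- Compound 1 `CCOC(=O)c1c(-c2cccc(Oc3ccccc3)c2)[nH]c2cc(OC)c(F)cc2c1=O` gives > 21500 nM as a limit
- Compound 2 `CCOC(=O)c1c(-c2cccc(-c3c(C)cccc3C)c2)[nH]c2cc(OC)c(F)cc2c1=O` gives > 21500 nM as a limit
- Compound 3 `CCOC(=O)c1c(-c2cccc(-c3nc(C)c(C)s3)c2)[nH]c2cc(OC)c(F)cc2c1=O` gives > 21500 nM as a limit

Compound 3 therefore has no number in this assay and stands only at a limit, in the same place as the whole set: the limit of > 21500 nM in this assay, at which 3 of the 3 values shown sit, and no value lies anywhere else.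

Compound 4 `CCOC(=O)c1c(-c2cccc(Cc3nc(C)c(C)s3)c2)[nH]c2cc(OC)c(F)cc2c1=O` differs from compound 3 at one site, on an aromatic carbon of a six-membered aromatic ring of carbon only, meta to a large group: a group of 8 heavy atoms (6 carbon, 1 nitrogen, 1 sulfur; one five-membered aromatic ring with 2 hetero atoms) in place of a group of 7 heavy atoms (5 carbon, 1 nitrogen, 1 sulfur; one five-membered aromatic ring with 2 hetero atoms), on an aromatic carbon and the rest of the structure stays the same.

Among the measured compounds shown here, three measured steps bear on this site: a step that the two limits leave unreadable from compound 1 to compound 2 and a step that the two limits leave unreadable from compound 1 to compound 3 and also a step that the two limits leave unreadable from compound 2 to compound 3 as the closest one. None of them has a readable size, yet all three compounds end at the same limit. No step beyond the scatter is therefore expected in this assay and no direction can be given. The estimated change is a step that the limit leaves unreadable from compound 3 to compound 4 and it is expected to be small. For compound 4 the expected value is 27000 nM with an estimated range from 12000 nM to 60000 nM and a report of a limit alone is the likeliest outcome.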

Compound 4, half-maximal effective concentration: > 21500 nM
Compound 4: only a limit was reported; the forecaster's own chance of this, stated with the estimate: 85%; the middle value does not contradict the limit.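

In this assay compound 4 gives > 21500 nM, which is a limit. No step from compound 1, compound 2 or compound 3 to compound 4 can be read, and all four stand at the same place: the limit of > 21500 nM in this assay, at which 4 of the 4 values shown sit.

The compounds shown leave open how far any of them lies beyond that limit, and so whether these groups differ at all in this assay.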